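This account rests on a few compounds, and the source may have more. Where it says the series, first, only, none or still open, it means among the compounds named here.

Working notes on the series, read in an ADME assay on the whole organism (Rattus norvegicus), at a dose of 2 mg/kg by the oral route; a lower number here means less compound in the circulation, a higher number more compound in the circulation at the dose given. Among the compounds with values here, compound 1 `COc1cc(OCc2cccc(-c3ccc(C(F)(F)F)cn3)c2)c2cc(-c3cn4nc(OC)sc4n3)oc2c1` gives 459 ng.h/mL and compound 2 `COc1cc(OCc2cccc(-c3ccc(C#N)cn3)c2)c2cc(-c3cn4nc(OC)sc4n3)oc2c1` gives 464 ng.h/mL, so compound 2 stands level with the only other measured compound. The next compound, compound 3 `COc1cc(OCc2cccc(-c3cnc(OC)cn3)c2)c2cc(-c3cn4nc(OC)sc4n3)oc2c1`, keeps the shared core and carries 5-methoxypyrazin-2-yl in place of 5-cyanopyridin-2-yl on an aromatic carbon. Within the data shown here, the one measured step, a 1.0-fold higher number from compound 1 to compound 2 (0.00 log units; within the scatter), replaces trifluoromethyl with cyano and lies within the scatter. Among the measured compounds shown here, it bears only partly on the new change, since it leaves the ring in place, and no measured compound carries the entering group. For the measured compounds named here, with only that flat step as a guide, the expected change is a 1.2-fold lower number from compound 2 to compound 3 (0.06 log units; within the scatter), with no direction expected beyond the scatter. Compound 3 is estimated at 400 ng.h/mL, with an expected range of 150 ng.h/mL to 1000 ng.h/mL.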

Compound 3, area under the concentration-time curve: 722 ng.h/mL
The estimate for compound 3 lay 1.8-fold (0.26 log units) below the measured number, within the range that was stated.
By their numbers in this assay, from the lowest: compounds 1, 2 and 3 (each within the scatter of the next).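

With 5-methoxypyrazin-2-yl entering on this aromatic carbon, this assay shows a 1.6-fold higher number from compound 2 to compound 3 (0.19 log units; within the scatter) against 5-cyanopyridin-2-yl and a 1.6-fold higher number from compound 1 to compound 3 (0.20 log units; within the scatter) against 5-(trifluoromethyl)pyridin-2-yl. The earlier step changed only the group on the pyridine ring, whereas these two steps exchange the ring and its group together and still stay within the scatter, so the position has now taken a change of ring as well as a change of group. Nothing measured here speaks to the reason for these numbers.

The ring's extra nitrogen and the methoxy group enter together, so the compounds shown do not separate the two. On these data alone, whether an amine, a carboxylic acid or a longer alkoxy chain on this ring would give a step beyond the scatter remains open.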